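The source may report more compounds than this note shows. Statements on the series, on what has been measured and on what is new or still open speak of the compounds shown alone.

Compound 1 `CCCCCCCCCCCCCCCCCC/N=c1\nc(N)c2nc[nH]c2c(N)n1` is the reference point of this small set. In a functional assay on MDA-MB-231 cells (Homo sapiens) for antiproliferative activity, read by WST assay, with a stated time of 72 h (a higher number here means a weaker inhibitor, a lower number a stronger inhibitor), compound 1 gives 1430 nM, the lowest of the three numbers recorded. Compound 2 `CCCCCCCCCCCCCCCCCC/N=c1\nc(N)c2ncn(Cc3ccccc3)c2c(N)n1` carries a benzyl group on an aromatic nitrogen of the shared core, and in this assay compound 2 gives 5400 nM; the step of a 3.8-fold higher number from compound 1 to compound 2 (0.58 log units; beyond the scatter) is a modest weakening that lies beyond the scatter. Compound 3 `CCCCCCCC/N=c1\nc(N)c2ncn(Cc3ccc(OC)cc3)c2c(N)n1` has a shorter chain together with a methoxybenzyl group on the same nitrogen, and in this assay compound 3 gives 2550 nM, a number within the scatter of compound 1.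

Compound 4 `CCCCCCCC/N=c1\nc(N)c2nc[nH]c2c(N)n1` differs from compound 1 only in the chain: hydrogen in place of decyl on a saturated chain carbon, eight bonds along the chain from a double-bonded nitrogen. Within the data shown here, no measured pair isolates this change. Compound 3 shows that a shorter chain combined with a ring substituent lands near compound 1, while the ring substituent alone in compound 2 raised the number; what the chain contributes on its own is therefore not fixed by these data. The expected outcome for compound 4 is a step of a 1.5-fold higher number from compound 1 to compound 4 (0.19 log units; within the scatter) that stays within or close to the scatter. Compound 4 is estimated to give 2200 nM in this assay, with a likely range from 800 nM to 6500 nM.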

Compound 4, half-maximal inhibitory concentration: "not active" (no number reported)
Compound 4: no number reported; no gap can be computed for the estimate.
By their numbers in this assay, from the lowest: compounds 1 and 3 (each within the scatter of the next); then compound 2.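

In this assay, among these compounds, compound 4 is reported as "not active" with no number, so no step from compound 1 to compound 4 can be read. Nothing given here bears on why this result arose. As far as these compounds go, how far hydrogen in place of decyl alone shifts the number, and how compound 4 ranks against compounds 2 and 3, remains open.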